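Replacing 1H-imidazol-1-yl in compound 2

The source may hold more compounds than are shown below. What is called first, only, known or untested is meant among the compounds shown, and "the series" means these compounds.

Measured so far:
- compound 1 `COC(=O)C1=C(CN2CCC(O)CC2)NC(c2nccs2)=NC1(C)c1ccc(F)cc1`: 593 ug/mL
- compound 2 `COC(=O)C1=C(Cn2ccnc2)NC(c2nccs2)=NC1(C)c1ccc(F)cc1`: 338 ug/mL

Both compounds were measured in a physicochemical assay for solubility, read by HPLC, in phosphate buffer, at pH 6.5; a lower number here means a less soluble compound, a higher number a more soluble compound. The two differ only in the group on a saturated chain carbon bound to a double-bonded ring carbon, and compound 2 stands within the scatter of compound 1. On these numbers, the two cannot be told apart.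

The next compound, compound 3 `COC(=O)C1=C(COC2CCOC2)NC(c2nccs2)=NC1(C)c1ccc(F)cc1`, keeps the core of compound 2 but carries (oxolan-3-yl)oxy in place of 1H-imidazol-1-yl at that same place: (oxolan-3-yl)oxy in place of 1H-imidazol-1-yl on a saturated chain carbon bound to a double-bonded ring carbon.

Going by the values given here, only one measured step bears on this change: a 1.8-fold lower number from compound 1 to compound 2 (0.24 log units; within the scatter). That step put 1H-imidazol-1-yl in place of 4-hydroxypiperidin-1-yl and did not go beyond the scatter. Among the compounds with values here, no measured compound carries (oxolan-3-yl)oxy, so this single step is a thin guide and the range must stay wide. In this assay, no step beyond the scatter is therefore expected, and the expected step is a 1.4-fold lower number from compound 2 to compound 3 (0.13 log units; within the scatter). For compound 3 the estimated value is 250 ug/mL, with an expected range from 80 ug/mL to 600 ug/mL.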

Compound 3, solubility: 30 ug/mL
Compound 3: the middle estimate sits 8.3-fold (0.92 log units) above what was measured, and the stated range ends above it.
By their numbers in this assay, from the lowest: compound 3; then compounds 2 and 1 (each within the scatter of the next).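

In this assay, the group on a saturated chain carbon bound to a double-bonded ring carbon proved able to move the number well beyond the scatter, which the earlier pair had not shown: (oxolan-3-yl)oxy in place of 1H-imidazol-1-yl gave an 11-fold lower number from compound 2 to compound 3 (1.05 log units; beyond the scatter), and in place of 4-hydroxypiperidin-1-yl it gave a 20-fold lower number from compound 1 to compound 3 (1.30 log units; beyond the scatter). The first of these changes leaves the hydrogen-bond donor and acceptor counts the same and no net charge on either group, so those counts do not separate the two; what differs is that a non-aromatic ring with oxygen atoms replaces an aromatic ring with nitrogen atoms. Among these three compounds, the two groups containing nitrogen stand within the scatter of each other and the group containing only oxygen stands apart, although no measurement given here explains the difference.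

The compounds shown leave open whether the nitrogen atoms, the ring or the ether link matters most. A dimethylamino group or an open-chain methoxyethoxy group at this place would help to separate these features.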